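From pyrimidin-5-yl to pyrimidin-2-yl on an amine nitrogen

The source may hold more compounds than are shown below. What is called first, only, known or untested is meant among the compounds shown, and "the series" means these compounds.

Three compounds sharing one core come with entries in an ADME assay on L02 cells (Homo sapiens) for cytotoxicity, read by CCK-8 assay, with a stated time of 6 days (a lower number here means a stronger inhibitor, a higher number a weaker inhibitor), and only one of them holds a reading. Compound 1 `COC(=O)/C=C/C(=O)N[C@@H](C)Cn1ccc(-c2ccc(C#N)c(Cl)c2)n1` has the entry "not determined" (no result reported) and so gives no result. Compound 2 `C[C@@H](Cn1ccc(-c2ccc(C#N)c(Cl)c2)n1)NS(=O)(=O)c1cn(C)cn1` has the entry "not determined" (no result reported) and also gives no result. Compound 3 `C[C@@H](Cn1ccc(-c2ccc(C#N)c(Cl)c2)n1)Nc1cncnc1` stands at > 30000 nM in this assay and this reading is a limit, not a number. Among the measured compounds shown here, the whole record thus comes down to the limit of > 30000 nM in this assay, at which 1 of the 3 values shown sits, and there is no measured step between compounds to lean on.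

Compound 4 `C[C@@H](Cn1ccc(-c2ccc(C#N)c(Cl)c2)n1)Nc1ncccn1` has the same atoms as compound 3, joined differently. The change pyrimidin-2-yl in place of pyrimidin-5-yl on an amine nitrogen amounts to pyrimidin-2-yl in place of pyrimidin-5-yl on an amine nitrogen.

For the measured compounds named here, the reading of compound 3 at > 30000 nM is a limit and the only guide, so no step beyond the usual scatter is expected in this assay and no direction can be favoured. The expected step of a number no higher from compound 3 to compound 4 (the limit leaves the size open) is therefore a small one, and a reading that is again only a limit is quite possible. The estimated value for compound 4 is 30000 nM with an expected range from 12000 nM to 60000 nM as the likely span of a measurement.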

Compound 4, half-maximal inhibitory concentration: > 30000 nM
Compound 4: no number, only a limit; the forecaster's own chance of this, stated with the estimate: 70%; the middle value lies on the limit itself.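

Compound 3 and compound 4 each give only a limit and not a number, so no step can be read between them: the limit of > 30000 nM in this assay, at which 2 of the 4 values shown sit.

The compounds shown leave open whether pyrimidin-2-yl and pyrimidin-5-yl on an amine nitrogen differ at all in this assay, and what number either compound would give.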